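Dimethylcarbamoyl in place of thiophen-2-yl on compound 3

A few compounds are considered here, and "the series" means these few. Any claim that something is new, unique, unknown or untested is made for them only; others in the source may bear on it.

In an ADME assay (Rattus norvegicus, strain Han-wistar) for pharmacokinetics, at a dose of 1.5 umol/kg by the intravenous route (a lower number here means slower removal, a higher number faster removal of the compound), compound 3 `CC(C)n1cc(-c2ccnc3[nH]c(C4CCN(Cc5cccs5)CC4)cc23)ccc1=O` gives 92 mL/min/kg. That lies within the scatter of compound 1 `CNC(=O)CN1CCC(c2cc3c(-c4ccc(=O)n(C(C)C)c4)ccnc3[nH]2)CC1`, at 89 mL/min/kg, and of compound 2 `COc1cc(F)ccc1-c1ccnc2[nH]c(C3CCN(CC(=O)N(C)C)CC3)cc12`, at 51 mL/min/kg. Compound 4 `CC(C)n1cc(-c2ccnc3[nH]c(C4CCN(CC(=O)N(C)C)CC4)cc23)ccc1=O` carries dimethylcarbamoyl in place of thiophen-2-yl on a saturated chain carbon bound to an amine nitrogen in a ring. For the measured compounds named here, the one measured step bearing on this is a 1.0-fold higher number from compound 1 to compound 3 (0.01 log units; within the scatter), with thiophen-2-yl in place of methylcarbamoyl. Compound 2 also carries dimethylcarbamoyl, but its core differs, so it bears only loosely. No change beyond the scatter is therefore expected in this assay. The expected step is a 1.2-fold lower number from compound 3 to compound 4 (0.09 log units; within the scatter). For compound 4 the estimate is 75 mL/min/kg, with an expected range from 45 mL/min/kg to 110 mL/min/kg.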

Compound 4, clearance: 77 mL/min/kg
Compound 4: middle estimate off by 1.0-fold (0.01 log units), on the low side; measured number inside the range.
By their numbers in this assay, from the lowest: compounds 2, 4, 1 and 3 (each within the scatter of the next).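

In this assay the chain carbon bound to an amine nitrogen in a ring accepts dimethylcarbamoyl for thiophen-2-yl with a 1.2-fold lower number from compound 3 to compound 4 (0.08 log units; within the scatter) and no more than that. Methyl in place of hydrogen on the amide-type nitrogen gives a 1.2-fold lower number from compound 1 to compound 4 (0.06 log units; within the scatter) and the group change on the aromatic carbon gives a 1.5-fold higher number from compound 2 to compound 4 (0.18 log units; within the scatter) among these compounds, so none of the three changes leaves the scatter. Going by these compounds, whether an amine or a carboxylic acid at this chain carbon would shift clearance stays open. No measured evidence here accounts for these steps.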